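Bromo on the 4-hydroxyphenyl group of compound 2

The source may report more compounds than this note shows. Statements on the series, on what has been measured and on what is new or still open speak of the compounds shown alone.

In a functional assay on HepG2 cells (Homo sapiens) for antiproliferative activity, read by MTT assay, with a stated time of 24 h (a higher number here means a weaker inhibitor, a lower number a stronger inhibitor), compound 1 (`COc1ccc(C(=O)/C=C/c2ccc(Cl)c(Cl)c2)c2c1C=CC(C)(C)O2`) gives > 10000 nM, which is a limit and not a number. In this assay compound 2 (`COc1ccc(C(=O)/C=C/c2ccc(O)cc2)c2c1C=CC(C)(C)O2`) gives > 10000 nM, again only a limit. Within the data shown here, the series so far therefore rests on (the limit of > 10000 nM in this assay, at which 2 of the 2 values shown sit), and compound 2 has no readable position of its own. Compound 3 (`COc1ccc(C(=O)/C=C/c2ccc(O)c(Br)c2)c2c1C=CC(C)(C)O2`) differs from it by bromo in place of hydrogen on an aromatic carbon, ortho to a hydroxy group, giving 3-bromo-4-hydroxyphenyl from 4-hydroxyphenyl. Among the measured compounds shown here, the only measured step that bears on this is a step that the two limits leave unreadable from compound 1 to compound 2, and it offers no size to carry over. For the measured compounds named here, no step of readable size or firm direction is therefore expected in this assay. Compound 3 is estimated at 10000 nM, with an expected range from 3000 nM to 30000 nM. The expected step is a number no higher from compound 2 to compound 3 (the limit leaves the size open), and a result reported only as a limit is considered likely.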

Compound 3, half-maximal inhibitory concentration: > 10000 nM
Compound 3: a limit, no number (the forecaster's own chance of this, stated with the estimate: 65%); the middle value lies on the limit itself.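

Among these compounds, no step among compound 1, compound 2 and compound 3 can be read, as all three give only a limit and no number: the limit of > 10000 nM in this assay, at which 3 of the 3 values shown sit. The compounds shown leave open whether bromo in place of hydrogen on the 4-hydroxyphenyl group alters antiproliferative activity at all.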